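Chain methylation and cytotoxicity across two analogue pairs

A few compounds are considered here, and "the series" means these few. Any claim that something is new, unique, unknown or untested is made for them only; others in the source may bear on it.

Compound 1 `Cc1c(Cc2cccc(Br)c2)nc(SCc2ccc([N+](=O)[O-])cc2)[nH]c1=O` and compound 3 `CCc1c(Cc2cccc(Br)c2)nc(SCc2ccc([N+](=O)[O-])cc2)[nH]c1=O` differ by methyl in place of hydrogen on a saturated chain carbon bound to an aromatic carbon. In an ADME assay on MT4 cells (Homo sapiens) for cytotoxicity, read by MTT assay (on this read-out lower numbers stand for higher toxicity in this test and higher numbers for lower toxicity in this test), compound 1 gives > 280000 nM, which is a limit of the assay. Compound 3 gives 187000 nM in this assay. The resulting step is an at least 1.4-fold lower number from compound 1 to compound 3 (0.17 log units; that floor lies within the scatter). Compound 2 `COc1ccc(CSc2nc(Cc3cc(C(F)(F)F)cc(C(F)(F)F)c3)c(C)c(=O)[nH]2)cc1` has a different core; the difference between the two cores is not broken down here. In this assay compound 2 gives > 256000 nM, a limit of the assay (the limit of > 256000 nM in this assay, at which 1 of the 3 values shown sits). Compound 4 `CCc1c(Cc2cc(C(F)(F)F)cc(C(F)(F)F)c2)nc(SCc2ccc(OC)cc2)[nH]c1=O` differs from compound 2 by methyl in place of hydrogen on a saturated chain carbon bound to an aromatic carbon, the same change as from compound 1 to compound 3. The expected step of an at least 1.2-fold lower number from compound 2 to compound 4 (0.10 log units; that floor lies within the scatter) is estimated to be of similar size. This rests on an at least 1.4-fold lower number from compound 1 to compound 3 (0.17 log units; that floor lies within the scatter). For compound 4 the estimated value is 200000 nM, expected between 100000 nM and 320000 nM, and this assay may again report only a limit.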

Compound 4, half-maximal cytotoxic concentration: > 249000 nM
Compound 4: only a limit was reported; the forecaster's own chance of this, stated with the estimate: 55%; middle value at least 1.2-fold (0.09 log units) from the limit.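

For the compounds shown here, compound 2 and compound 4 are both reported only as limits of the assay, so no step between them can be read. The compounds shown leave open what size, if any, the methyl-for-hydrogen step has in this pair.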